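This account rests on a few compounds, and the source may have more. Where it says the series, first, only, none or still open, it means among the compounds named here.

Compound 1 `COc1ccc(CN2C(=O)C(=O)c3cc(-c4ccc(OC)cc4)ccc32)cc1` gives 30 nM in a functional assay on K562 cells (Homo sapiens) for antiproliferative activity, read by MTT assay, with a stated time of 48 h (on this read-out lower numbers stand for stronger inhibition and higher numbers for weaker inhibition), the lowest of the two numbers measured. Its nearest neighbour is compound 2 `COc1ccc(-c2ccc3c(c2)C(=O)C(=O)N3Cc2ccc(OC)c(OC)c2)cc1`, which gives 60 nM in this assay; the step of a 2.0-fold higher number from compound 1 to compound 2 (0.30 log units; within the scatter) stays within the scatter. Compound 3 `COc1ccc(CN2C(=O)C(=O)c3cc(-c4ccc(C#N)cc4)ccc32)cc1` is compound 1 altered at one place: cyano in place of methoxy on an aromatic carbon. Going by the values given here, no measured step touches this exchange, in which 4-methoxyphenyl becomes 4-cyanophenyl, so the only guide is compound 1 itself. Compound 3 is therefore expected to show a 1.3-fold higher number from compound 1 to compound 3 (0.12 log units; within the scatter) in this assay, with wide uncertainty. The estimated value for compound 3 is 40 nM, between 12 nM and 130 nM.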

Compound 3, half-maximal inhibitory concentration: 260 nM
For compound 3 the middle estimate is 6.5-fold (0.81 log units) below the measured one; measured number above the stated range.
By their numbers in this assay, from the lowest: compounds 1 and 2 (each within the scatter of the next); then compound 3.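

Going by these compounds alone, the group at this place on the ring matters: in this assay, cyano in place of methoxy gives an 8.7-fold higher number from compound 1 to compound 3 (0.94 log units; beyond the scatter), whereas the only earlier step, made elsewhere in the molecule, stayed within the scatter. Methoxy and cyano have the same count of heavy atoms and of hydrogen-bond acceptors, so these counts do not separate the two groups. Nothing measured here accounts for the change. Going by these compounds, it remains open how an amine or a carboxylic acid at this place would compare with methoxy. On these data alone, whether the same exchange would give a similar step on compound 2 is also open.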